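Working notes: methyl for methoxy on compound 4

This account rests on a few compounds, and the source may have more. Where it says the series, first, only, none or still open, it means among the compounds named here.

Measured in a functional assay on the whole organism for inhibition, with Digitaria ciliaris as the target, with a stated time of 72 h, tested at 100 mg/L; a lower number here means less inhibition of growth, a higher number more inhibition of growth at the concentration tested:
compound 1 `Cc1cc(O)nc(NC(=S)NC(=O)c2c(-c3ccc(Cl)cc3Cl)noc2C)n1` gives 49.3%
compound 2 `COc1cc(C)nc2n/c(=N/C(=O)c3c(-c4ccc(Cl)cc4Cl)noc3C)sn12` gives 80.6%
compound 3 `COc1cc(SC)nc(NC(=S)NC(=O)c2c(-c3ccc(Cl)cc3Cl)noc2C)n1` gives 55.6%

Compound 3 stands second highest of the three numbers. Its nearest neighbour is compound 1, with a number 6.3 percentage points higher from compound 1 to compound 3 (within the scatter), a step within the scatter. Compound 2 lies clearly higher, its value beyond the scatter from that of compound 3; no single-point change links those two.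

Compound 4 `CSc1cc(C)nc(NC(=S)NC(=O)c2c(-c3ccc(Cl)cc3Cl)noc2C)n1` differs from compound 3 by methyl in place of methoxy on an aromatic carbon. Among the measured compounds shown here, the only measured step that touches the same ring is a number 6.3 percentage points higher from compound 1 to compound 3 (within the scatter), and it changed two groups at once while staying within the scatter. For the measured compounds named here, no measured pair swaps methoxy for methyl alone, so nothing in hand points in either direction. The expectation is therefore no step beyond the scatter in this assay, estimated as a number 0.6 percentage points lower from compound 3 to compound 4 (within the scatter). Compound 4 is expected at 55%, with a range from 35% to 75%.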

Compound 4, percent growth inhibition at one concentration: 45.5%
Compound 4: the middle estimate sits 9.5 percentage points above what was measured; the measured number falls inside the stated range.
By their numbers in this assay, from the lowest: compounds 4, 1 and 3 (each within the scatter of the next, the first and the last beyond it); then compound 2.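

In this assay, among the compounds shown here, the methoxy group on this aromatic carbon is the first single group tested alone, and methyl in its place gives a number 10.1 percentage points lower from compound 3 to compound 4 (beyond the scatter) with a modest loss of growth inhibition. The position is therefore not indifferent to this change, although the step lies only just beyond the scatter and rests on one pair. Methylsulfanyl in place of hydroxy on an aromatic carbon gives a number 3.8 percentage points lower from compound 1 to compound 4 (within the scatter) and, read alone, shows no separable effect; no measured property is at hand to account for either step.

The compounds shown leave open whether an amine or an ethoxy group on this carbon would read closer to methoxy or to methyl. They also leave open how compound 2 at 80.6% connects by single changes to the rest of the series.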